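Swapping a methyl for oxan-4-yl on an amine nitrogen

The source may report more compounds than this note shows. Statements on the series, on what has been measured and on what is new or still open speak of the compounds shown alone.

Compound 1 `NC(=O)NCCCCN(C[C@H]1Cc2ncccc2CN1)[C@H]1CCCc2cccnc21`: 91%
Compound 2 `NC(=O)NC/C=C\CN(C[C@H]1Cc2ncccc2CN1)[C@H]1CCCc2cccnc21`: 100%
Compound 3 `CN(C)CCCCN(C[C@H]1Cc2ncccc2CN1)[C@H]1CCCc2cccnc21`: 100%

In an ADME assay on microsomes from liver (Homo sapiens) for metabolic stability, using NADPH, with a stated time of 10 min (on this read-out higher numbers stand for a more stable compound and lower numbers for a less stable compound), compound 3 gives 100%, the same reading as compound 2, and all three values lie within the scatter of each other. Compound 4 `CN(CCCCN(C[C@H]1Cc2ncccc2CN1)[C@H]1CCCc2cccnc21)C1CCOCC1` departs from compound 3 with oxan-4-yl in place of methyl on an amine nitrogen.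

For the measured compounds named here, no measured step makes this exact change, so the evidence is indirect. The closest is a number 9 percentage points higher from compound 1 to compound 3 (within the scatter), where dimethylamino stands in place of ureido. The other two are a number 9 percentage points higher from compound 1 to compound 2 (within the scatter) and no change at the digits printed from compound 2 to compound 3 (within the scatter). All three stayed within the scatter, and none introduces a ring, so the data cannot exclude a larger effect.

The expected step is a number 8 percentage points lower from compound 3 to compound 4 (within the scatter), an estimate that does not go beyond the scatter. For compound 4 the estimated value in this assay is 92%, with an expected range of 75% to 100%.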

Compound 4, percent of the compound remaining: 100%
The estimate for compound 4 lay 8 percentage points below the measured number, and the stated range covers the measured number.
By their numbers in this assay, from the lowest: compounds 1, 2, 3 and 4 (each within the scatter of the next).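

Of the compounds shown, only compound 4 carries a ring at this place, and oxan-4-yl in place of methyl on the amine nitrogen gave no change at the digits printed from compound 3 to compound 4 (within the scatter) in this assay. The larger group thus leaves the reading where dimethylamino had it, and the comparisons with the other chain ends agree, with no change at the digits printed from compound 2 to compound 4 (within the scatter) and a number 9 percentage points higher from compound 1 to compound 4 (within the scatter), so all four compounds remain within the scatter of each other. Nothing available gives a reason for this reading.

With the readings this close together, the compounds leave open how far this amine nitrogen can be changed before the reading moves. A carboxylic acid at the end of the chain, an aromatic ring such as phenyl on the amine nitrogen, or a longer chain could still give a different result.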